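The compounds below may be only part of what the source reports. "The series", "measured", "known", "first", "only" and "open" are said of these compounds alone.

Measured compounds:

- Compound 1, `CCN(CC)CCCNCc1cn(-c2ccc(F)cc2F)nc1-c1ccccc1C`. In an ADME assay on Huh-7 cells (Homo sapiens) for cytotoxicity (on this read-out higher numbers stand for lower toxicity in this test and lower numbers for higher toxicity in this test), compound 1 gives > 20000 nM, which is a limit of the assay and not a number.
- Compound 2, `Cc1ccccc1-c1nn(-c2ccc(F)cc2F)cc1CNCCCCO`. In this assay compound 2 gives > 20000 nM, again a limit of the assay.
- Compound 3, `CCCCCNCc1cn(-c2ccc(F)cc2F)nc1-c1ccccc1C`. In this assay compound 3 gives 17000 nM.

Among the compounds with values here, compound 3 therefore holds the only real number among the three; the other two sit at the limit of > 20000 nM in this assay, at which 2 of the 3 values shown sit. The steps that lead to compound 3 are small: an at least 1.1-fold lower number from compound 1 to compound 3 (0.07 log units; that floor lies within the scatter) and an at least 1.1-fold lower number from compound 2 to compound 3 (0.07 log units; that floor lies within the scatter), both floors that lie within the scatter of repeated measurements. The step that the two limits leave unreadable from compound 1 to compound 2 cannot be read, since both of its values are limits.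

Compound 4, `Cc1ccccc1-c1nn(-c2ccc(F)cc2F)cc1CN1CCN(C(C)C)CC1`, is not yet measured. It differs from compound 3 by 4-isopropylpiperazin-1-yl in place of pentylamino on a saturated chain carbon bound to an aromatic carbon. Within the data shown here, none of the measured steps changes this part of the molecule in the same way, and the steps that are known are all within the scatter, so no shift beyond that scatter is expected in this assay in either direction. For compound 4 the estimate is 20000 nM, with a range from 8000 nM to 50000 nM, which corresponds to an expected step of a 1.2-fold higher number from compound 3 to compound 4 (0.07 log units; within the scatter).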

Compound 4, half-maximal cytotoxic concentration: > 20000 nM
Compound 4 ended at the assay's limit (the forecaster's own chance of this, stated with the estimate: 55%); the middle value sits exactly at the limit.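

Replacing pentylamino with 4-isopropylpiperazin-1-yl on a saturated chain carbon bound to an aromatic carbon gives an at least 1.1-fold higher number from compound 3 to compound 4 (0.07 log units; that floor lies within the scatter) in this assay. Compounds 1, 2 and 3 all carry an open chain on the amine at this place, whereas compound 4 carries a six-membered non-aromatic ring with 2 hetero atoms and 0 hydrogen-bond donors, and its result in this read-out is again a limit of the assay and not a number. The steps from compound 1 and from compound 2 to compound 4 cannot be read, as both ends of each are limits, and the shown results now cluster at one value: the limit of > 20000 nM in this assay, at which 3 of the 4 values shown sit.

Going by these compounds, with compound 3 the only one of the four to give a real number, it stays open how far the others lie from it and whether any group at this place brings a real shift in this read-out. A morpholine, or a piperazine without the isopropyl group, on the same carbon could help separate the part played by the ring from that of the isopropyl group.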